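From Allyl to Cyclopropylmethyl on the Sulfur Chain

This account rests on a few compounds, and the source may have more. Where it says the series, first, only, none or still open, it means among the compounds named here.

Three compounds share one core and differ only in the group on a saturated chain carbon bound to a sulfur. In a functional assay on MCF7 cells (Homo sapiens) for inhibition, read by MTT assay, with a stated time of 72 h (a higher number here means a weaker inhibitor, a lower number a stronger inhibitor), compound 1 `Cc1cc(Nc2cc(-c3ccccc3)[nH]n2)n2nc(SCc3ccccc3Br)nc2n1`, carrying 2-bromophenyl, gives 3020 nM. With 4-chlorophenyl, compound 2 `Cc1cc(Nc2cc(-c3ccccc3)[nH]n2)n2nc(SCc3ccc(Cl)cc3)nc2n1` gives 8260 nM, which is a 2.7-fold higher number from compound 1 to compound 2 (0.44 log units; beyond the scatter).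

Compound 3 `C=CCSc1nc2nc(C)cc(Nc3cc(-c4ccccc4)[nH]n3)n2n1`, carrying vinyl, is reported as > 50000 nM, which is a limit of the assay and not a number. Compound 3 therefore stands at the limit of > 50000 nM in this assay, at which 1 of the 3 values shown sits.

Swapping an aromatic group for vinyl gives an at least 16-fold higher number from compound 1 to compound 3 (1.21 log units; beyond the scatter) and also an at least 6.0-fold higher number from compound 2 to compound 3 (0.78 log units; beyond the scatter). Both are sizeable steps.

Compound 4 `Cc1cc(Nc2cc(-c3ccccc3)[nH]n2)n2nc(SCC3CC3)nc2n1` keeps the core and changes one group: cyclopropyl in place of vinyl on a saturated chain carbon bound to a sulfur. This is cyclopropyl in place of vinyl, or allyl to cyclopropylmethyl when cut one bond further out. Going by the values given here, no measured step compares two small groups without an aromatic ring, so those two steps bear on it only indirectly. Compound 4 also has no aromatic group in this place, so it is expected to remain close to compound 3, with a small shift towards a lower number. The expected change is an at least 1.4-fold lower number from compound 3 to compound 4 (0.15 log units; that floor lies within the scatter).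

In this assay the estimate for compound 4 is 35000 nM, with an expected range from 12000 nM to 80000 nM.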

Compound 4, half-maximal inhibitory concentration: > 50000 nM
Compound 4: a limit, no number; the forecaster's own chance of this, stated with the estimate: 50%; middle value at least 1.4-fold (0.15 log units) away from the limit.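

Compound 4 sits at a limit of this assay and not at a number, as does compound 3, so the step between them cannot be read and cyclopropyl and vinyl cannot be ranked at this place: the limit of > 50000 nM in this assay, at which 2 of the 4 values shown sit.

What compound 4 adds is a second small group without an aromatic ring that gives no measurable value, and the steps from the aromatic compounds are clear: 4-chlorophenyl to cyclopropyl gives an at least 6.0-fold higher number from compound 2 to compound 4 (0.78 log units; beyond the scatter), and 2-bromophenyl to cyclopropyl gives an at least 16-fold higher number from compound 1 to compound 4 (1.21 log units; beyond the scatter). Among these four compounds, the two with an aromatic ring on the saturated chain carbon bound to the sulfur give numbers and the two without one sit at the limit, and no compound shown goes against this split.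

From the compounds shown here alone, it remains open whether a plain phenyl without a halogen would give a number like those of compound 1 and compound 2, and whether a longer chain such as hexyl would also stay at the limit. A pyridine ring or a chain ending in an amine at this place would test how much of the aromatic ring's effect depends on carbon alone.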